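The source may hold more compounds than are shown below. What is called first, only, known or untested is meant among the compounds shown, and "the series" means these compounds.

In a functional assay on HepG2 cells (Homo sapiens) for antiproliferative activity, read by MTT assay, with a stated time of 72 h (on this read-out lower numbers stand for stronger inhibition and higher numbers for weaker inhibition), compound 3 (`O=C1COc2ccc(-c3cnc(Cl)c(NS(=O)(=O)c4ccc(F)cc4)c3)cc2N1c1ccc(F)cc1`) reports only a limit, > 40000 nM. Compound 1 (`COc1ccc(N2C(=O)COc3ccc(-c4cnc(Cl)c(NS(=O)(=O)c5ccc(F)cc5)c4)cc32)cc1`) also reports only a limit, > 40000 nM. Compound 2 (`COc1ncc(-c2ccc3c(c2)N(c2ccc(F)cc2)C(=O)CO3)cc1NS(=O)(=O)c1ccc(F)cc1`) gives a number, 36400 nM. Compound 4 (`O=C1COc2ccc(-c3cnc(Cl)c(NS(=O)(=O)c4ccc(F)cc4)c3)cc2N1C1CC1`) has cyclopropyl in place of 4-fluorophenyl on an amide-type nitrogen in a ring. Among the compounds with values here, only one measured step alters the group that leaves here: a step that the two limits leave unreadable from compound 1 to compound 3. The other measured step changes a different part of the molecule: an at least 1.0-fold higher number from compound 2 to compound 3 (0.04 log units; that floor lies within the scatter). Neither gives a readable size for this change, so no shift beyond the scatter is expected in this assay, and a further limit is quite likely. The expected step is an at least 1.0-fold lower number from compound 3 to compound 4 (0.02 log units; that floor lies within the scatter). For compound 4 the estimated value is 38000 nM, with an expected range of 14000 nM to 70000 nM.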

Compound 4, half-maximal inhibitory concentration: 8510 nM
Estimate against measurement, compound 4: 4.5-fold (0.65 log units) above, and the stated range ends above it.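

In this assay, within the data shown here, the amide-type nitrogen in a ring is the first place to give a readable shift: cyclopropyl in place of 4-fluorophenyl gives an at least 4.7-fold lower number from compound 3 to compound 4 (0.67 log units; beyond the scatter). Cyclopropyl in place of 4-methoxyphenyl gives an at least 4.7-fold lower number from compound 1 to compound 4 (0.67 log units; beyond the scatter), while the step between those two aryl compounds cannot be read. Both steps are floors set by a limit of the assay: the limit of > 40000 nM in this assay, at which 2 of the 4 values shown sit.

Open, on these data alone, is whether an ethyl chain or an amine on that nitrogen would match cyclopropyl. Also open, as far as these compounds go, is whether the step holds with methoxy in place of chloro, as in compound 2.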